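A few compounds are considered here, and "the series" means these few. Any claim that something is new, unique, unknown or untested is made for them only; others in the source may bear on it.

Measured so far, in a functional assay on PC-12 cells (Rattus norvegicus) for cytotoxicity, read by MTT assay, with stated times of 2 h and 24 h, tested at 10 uM; on this read-out higher numbers stand for a stronger effect at the one concentration tested and lower numbers for a weaker effect:

compound 1 `CCc1ccc(-n2nc(-c3ccc(C(F)(F)F)cc3O)nc2-c2ccccc2O)cc1` gives 107%
compound 2 `Oc1cc(C(F)(F)F)ccc1-c1nc(-c2ccccc2O)n(-c2ccccc2F)n1` gives 100%
compound 3 `Oc1cc(C(F)(F)F)ccc1-c1nc(-c2ccccc2O)n(-c2ccccc2C(F)(F)F)n1` gives 92.2%

Compound 1 stands highest of these three numbers. Its nearest neighbour is reached by the step of a number 7 percentage points lower from compound 1 to compound 2 (within the scatter), and its furthest by a number 14.8 percentage points lower from compound 1 to compound 3 (beyond the scatter); the two fluorinated compounds lie close to each other, as a number 7.8 percentage points lower from compound 2 to compound 3 (within the scatter) shows. All three compounds share one core, and the three differ only in the phenyl ring carried on an aromatic nitrogen of that core.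

Compound 4 `Oc1cc(C(F)(F)F)ccc1-c1nc(-c2ccccc2O)n(-c2cccc(F)c2)n1` is not yet measured. It differs from compound 1 in one place: 3-fluorophenyl in place of 4-ethylphenyl on an aromatic nitrogen. The two steps that bear on this change both swap out the same 4-ethylphenyl for a fluorinated phenyl; one stayed within the scatter, the other was modest and downward. A similar small step down, or none beyond the scatter, is therefore expected in this assay, namely a number 7 percentage points lower from compound 1 to compound 4 (within the scatter). Compound 4 is estimated at 100%, with a likely range from 88% to 112%.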

Compound 4, a percentage reported as activity, at one concentration (the size of the read-out at that concentration, not a potency): 98.3%
The estimate for compound 4 lay 1.7 percentage points above the measured number, within the range that was stated.
By their numbers in this assay, from the lowest: compounds 3, 4, 2 and 1 (each within the scatter of the next, the first and the last beyond it).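

Placing the fluoro group differently on the phenyl ring leaves the read-out in this assay unresolved, since replacing 2-fluorophenyl with 3-fluorophenyl gives a small step (a number 1.7 percentage points lower from compound 2 to compound 4 (within the scatter)). Compound 4 also stays within the scatter of the 4-ethylphenyl compound (a number 8.7 percentage points lower from compound 1 to compound 4 (within the scatter)) and of the 2-(trifluoromethyl)phenyl compound (a number 6.1 percentage points higher from compound 3 to compound 4 (within the scatter)), so it cannot be told apart from either, although those two compounds can be told apart from each other. Nothing available here explains these numbers.

From the compounds shown here alone, it remains open how this position would respond to a phenyl ring carrying an amine or a carboxylic acid, or to a longer chain in place of the ethyl group. Because each compound was read at one concentration, these numbers also leave potency open.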